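This account rests on a few compounds, and the source may have more. Where it says the series, first, only, none or still open, it means among the compounds named here.

Measured so far:

Compound 1 `COCCOC(=O)C(=O)Nc1nc(-c2cc(Br)no2)cs1` in a functional assay on the whole organism with Rattus norvegicus as the target (a lower number here means that less compound is needed, a higher number that more compound is needed for the effect), gives > 100 mg/kg, which is a limit of the assay and not a number.
Compound 2 `CCOC(=O)C(=O)Nc1nc(-c2cc(Br)no2)cs1` in this assay gives > 100 mg/kg, again a limit of the assay.
Compound 3 `CCOCCOC(=O)C(=O)Nc1nc(-c2cc(C)no2)cs1` in this assay gives 1.3 mg/kg.

Compound 2 and compound 1 share their core and differ by methoxy in place of hydrogen on a saturated chain carbon, two bonds along the chain from an oxygen next to a carbonyl group. The step that the two limits leave unreadable from compound 2 to compound 1 cannot be sized because the limit of > 100 mg/kg in this assay, at which 2 of the 3 values shown sit, covers both compounds.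

Compound 3 carries a different core; the difference between its core and that of compound 2 is not broken down here. Within the data shown here, compound 3 is the only compound with a readable number in this assay.

Compound 4 `CCOCCOC(=O)C(=O)Nc1nc(-c2cc(COC)no2)cs1` has not been measured. It differs from compound 3 by methoxy in place of hydrogen on a saturated chain carbon bound to an aromatic carbon. This is the same kind of change as that from compound 2 to compound 1, but not the same change: there the methoxy enters on a saturated chain carbon, two bonds along the chain from an oxygen next to a carbonyl group, while here it enters on a saturated chain carbon bound to an aromatic carbon. The measured pair offers no size to carry across, so the expectation rests on compound 3 with its value of 1.3 mg/kg as the only anchor, with the change treated as small on its own.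

The step of a 1.9-fold higher number from compound 3 to compound 4 (0.28 log units; within the scatter) is expected to stay within the usual scatter, leaning toward slightly more compound being needed.

Compound 4 is therefore estimated at 2.5 mg/kg, with a range from 0.8 mg/kg to 10 mg/kg.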

Compound 4, dose for half-maximal effect: 0.7 mg/kg
Estimate against measurement, compound 4: 3.6-fold (0.55 log units) above, and the stated range ends above it.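

In this assay, methoxy in place of hydrogen on a saturated chain carbon bound to an aromatic carbon gives a 1.9-fold lower number from compound 3 to compound 4 (0.27 log units; within the scatter), so on the core of compound 3 the methyl to methoxymethyl change leaves two values that cannot be told apart. Among these compounds, this shows only that the change is accommodated on this one core, in this one whole-organism read-out. Among the compounds shown here, it does not show that the result carries to another core: the only other methoxy step enters at a different place, on a saturated chain carbon, two bonds along the chain from an oxygen next to a carbonyl group, and with both of its compounds at a limit of the assay rather than a number, that step cannot be read, which leaves no second size to set beside this one: the limit of > 100 mg/kg in this assay, at which 2 of the 4 values shown sit.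

Open, going by these compounds, is how far the same saturated chain carbon bound to an aromatic carbon accepts other groups, such as a hydroxyl, an amine, a carboxylic acid or a longer chain like ethoxymethyl in place of methoxymethyl. Also open, on these data alone, is whether the methoxy change gives a comparable step on any further core that yields readable numbers in this assay.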